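Swapping the amino group on a sulfonyl sulfur

This account rests on a few compounds, and the source may have more. Where it says the series, first, only, none or still open, it means among the compounds named here.

In a toxicity assay on Vero cells (Chlorocebus sabaeus) for cytotoxicity, read by MTT assay (on this read-out lower numbers stand for stronger inhibition and higher numbers for weaker inhibition), compound 2 `CCN(C)S(=O)(=O)c1ccc(C(=O)Nc2sccc2C(=O)NC(=O)OC)cc1` gives 10.4 ug/mL and compound 1 `COC(=O)NC(=O)c1ccsc1NC(=O)c1ccc(S(=O)(=O)N2CCC2)cc1` gives 17.5 ug/mL with the two values within the scatter of each other. The change to compound 3 `COC(=O)NC(=O)c1ccsc1NC(=O)c1ccc(S(=O)(=O)NC2CCC(F)(F)CC2)cc1` is (4,4-difluorocyclohexyl)amino in place of ethyl(methyl)amino on a sulfonyl sulfur and it puts (4,4-difluorocyclohexyl)amino in place of ethyl(methyl)amino on a sulfonyl sulfur. For the measured compounds named here, the one measured step at this place is a 1.7-fold lower number from compound 1 to compound 2 (0.23 log units; within the scatter) and it is small, though no measured compound carries the entering group. The expected step of a 1.2-fold higher number from compound 2 to compound 3 (0.06 log units; within the scatter) is therefore none beyond the scatter. For compound 3 the estimate is 12 ug/mL with 4 ug/mL to 35 ug/mL as the expected range.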

Compound 3, half-maximal inhibitory concentration: 49 ug/mL
Beside the measured number, compound 3's estimate is 4.1-fold (0.61 log units) below it; measured number outside the range, above it.
By their numbers in this assay, from the lowest: compounds 2 and 1 (each within the scatter of the next); then compound 3.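

Up to now, the swap of amino group on the sulfonyl sulfur had moved the number in this assay only within the scatter. With (4,4-difluorocyclohexyl)amino there is a 4.7-fold higher number from compound 2 to compound 3 (0.67 log units; beyond the scatter) and a 2.8-fold higher number from compound 1 to compound 3 (0.45 log units; beyond the scatter), so this position does respond to the group it carries, and here the change goes toward weaker inhibition. Nothing available explains why.

The compounds shown leave open which part of the entering group goes with the higher number: the six-membered ring, the two fluorine atoms or the hydrogen-bond donor. Plain cyclohexylamino, without fluorine, and piperidin-1-yl, without the donor, would help separate these.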